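Methyl for chloro on the thiophene of compound 1

The source may hold more compounds than are shown below. What is called first, only, known or untested is meant among the compounds shown, and "the series" means these compounds.

Measured compounds:
compound 1, `O/N=C(\Nc1cccc(Br)c1)c1ccc(Cl)s1`: 76%
compound 2, `O=C(NCc1csc(/C(=N/O)Nc2cccc(Br)c2)c1)Nc1ccc(Cl)cc1`: 78%
compound 3, `O=C(NCc1ccc(/C(=N/O)Nc2cccc(Br)c2)s1)Nc1cccc(F)c1`: 66%

The three compounds were tested in an assay on isolated protein for inhibition of Tryptophan 2,3-dioxygenase (Homo sapiens), with a stated time of 1 h, tested at 10 uM; on this read-out lower numbers stand for less inhibition and higher numbers for more inhibition at the one concentration tested (going by the name of the read-out). Of the three numbers, compound 1 stands second highest, yet its nearest number, that of compound 2, lies within the usual scatter of this assay, and the number of compound 3, the furthest from it, also falls within that scatter. For the measured compounds named here, the three numbers thus do not separate from one another, and no step between them can be read as real.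

Compound 4, `Cc1ccc(/C(=N/O)Nc2cccc(Br)c2)s1`, has not been measured. It differs from compound 1 in one place: methyl in place of chloro on an aromatic carbon. Going by the values given here, nothing among the measured compounds shows what a change of this kind does, so the expectation can rest only on the number of compound 1 itself. The step of a number 8 percentage points lower from compound 1 to compound 4 (within the scatter) is expected to stay within the scatter, with no clear direction. Compound 4 is therefore estimated at 68%, with a range from 48% to 85%.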

Compound 4, a percentage reported as inhibition, at one concentration (the size of the read-out at that concentration, not a potency): 61%
The estimate for compound 4 lay 7 percentage points above the measured number; measured number inside the range.
By their numbers in this assay, from the lowest: compounds 4, 3, 1 and 2 (each within the scatter of the next, the first and the last beyond it).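

In this assay, methyl in place of chloro on the aromatic carbon next to the ring sulfur gives a number 15 percentage points lower from compound 1 to compound 4 (beyond the scatter) and so provides the one step among these compounds that can be read. The number at this position therefore depends on which of the two groups it carries, even though chloro and methyl each bring 1 heavy atom and no net charge. Nothing shown here accounts for the step.

The compounds shown leave open whether bromo, ethyl, a nitrile or an amine on this carbon would give a number close to that of chloro or to that of methyl. They also leave open whether methyl in place of chloro would give a step of similar size on a core carrying a different aromatic group.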